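The compounds below may be only part of what the source reports. "The series", "measured", "known", "first", "only" and "open" are said of these compounds alone.

Working notes on the series.

Compound 1 `Cc1noc(C)c1-c1cnc(N)c(Oc2ccc(C(=O)Nc3ccc(Cl)cc3)cc2)n1` gives 2230 nM in a functional assay on HeLa cells (Homo sapiens) for inhibition, read by MTT assay, with a stated time of 72 h; a lower number here means a stronger inhibitor, a higher number a weaker inhibitor. Compound 2 `Cc1noc(C)c1-c1cnc(N)c(Oc2ccc(C(=O)Nc3cccc(Cl)n3)cc2)n1` gives 25500 nM, and compound 3 `Cn1cc(-c2cnc(N)c(Oc3ccc(C(=O)Nc4ccc(Cl)cc4)cc3)n2)cn1` gives 3440 nM. Among the three numbers in hand, compound 3 stands second highest; its nearest neighbour is compound 1 a 1.5-fold higher number from compound 1 to compound 3 (0.19 log units; within the scatter), while compound 2 lies far from it an 11-fold higher number from compound 1 to compound 2 (1.06 log units; beyond the scatter) relative to compound 1.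

Compound 4 `Cn1cc(-c2cnc(N)c(Oc3ccc(C(=O)Nc4cccc(Cl)n4)cc3)n2)cn1` has not yet been measured. It differs from compound 3 in one place: 6-chloropyridin-2-yl in place of 4-chlorophenyl on an amide-type nitrogen. The same exchange on the amide-type nitrogen has been seen once before, from compound 1 to compound 2, where it gave an 11-fold higher number from compound 1 to compound 2 (1.06 log units; beyond the scatter). The other exchange in the set, on the aromatic carbon, stayed within the scatter a 1.5-fold higher number from compound 1 to compound 3 (0.19 log units; within the scatter), so the core change is not expected to alter how the amide-nitrogen exchange plays out.

A large rise in the number, in the direction of weaker inhibition, is therefore expected for compound 4, estimated as an 11-fold higher number from compound 3 to compound 4 (1.04 log units; beyond the scatter). On that basis the expected value for compound 4 is 38000 nM, with a range from 15000 nM to 95000 nM.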

Compound 4, half-maximal inhibitory concentration: 38200 nM
The estimate for compound 4 lay 1.0-fold (0.00 log units) below the measured number, and the stated range covers the measured number.
By their numbers in this assay, from the lowest: compounds 1 and 3 (each within the scatter of the next); then compounds 2 and 4 (each within the scatter of the next).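

With 1-methyl-1H-pyrazol-4-yl on the aromatic carbon, 6-chloropyridin-2-yl in place of 4-chlorophenyl on the amide-type nitrogen again gives a large step in the direction of weaker inhibition, an 11-fold higher number from compound 3 to compound 4 (1.05 log units; beyond the scatter), so this exchange no longer rests on one pair and its size carries over between the two cores: the same change on two cores in this assay, an 11-fold higher number (1.06 log units; beyond the scatter) from compound 1 to compound 2 and an 11-fold higher number (1.05 log units; beyond the scatter) from compound 3 to compound 4, 1.0-fold (0.01 log units) apart, within the scatter of two such steps

The exchange on the aromatic carbon, now read with 6-chloropyridin-2-yl on the amide-type nitrogen, gives a 1.5-fold higher number from compound 2 to compound 4 (0.18 log units; within the scatter), so it stays within the scatter on this second core as well: the same change on two cores in this assay, a 1.5-fold higher number (0.19 log units; within the scatter) from compound 1 to compound 3 and a 1.5-fold higher number (0.18 log units; within the scatter) from compound 2 to compound 4, 1.0-fold (0.01 log units) apart, within the scatter of two such steps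

For the compounds shown here, no compound among the four goes against the two exchanges acting independently.

Still open, going by these compounds, is whether the ring nitrogen or the place of the chlorine carries the large step; 3-chlorophenyl and 5-chloropyridin-2-yl on the same amide-type nitrogen would separate the two. Also open, on these data alone, is how an amine or a carboxylic acid in place of the chlorine would read.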